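Chloro in place of methyl: working notes on the series

A few compounds are considered here, and "the series" means these few. Any claim that something is new, unique, unknown or untested is made for them only; others in the source may bear on it.

Measured in a functional assay on A549 cells (Homo sapiens) for cytotoxicity, read by MTT assay, with a stated time of 68 h; on this read-out higher numbers stand for weaker inhibition and lower numbers for stronger inhibition
compound 1 `CSc1ccc(-c2cc(NC(=O)C(Cl)Cl)cc(-c3ccc(SC)cc3)c2)cc1` gives 22300 nM
compound 2 `Cc1ccc(-c2cccc(NC(=O)C(Cl)Cl)c2)cc1` gives 8300 nM
compound 3 `CCOc1cccc(-c2cc(NC(=O)C(Cl)Cl)cc(-c3cccc(OCC)c3)c2)c1` gives 8830 nM

Compound 2 at 8300 nM lies within the scatter of compound 3 at 8830 nM on this read-out. Compound 1 at 22300 nM carries a higher number than compound 2, and that gap lies beyond the scatter. With only these three values, no pattern across the series can be claimed.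

The next compound to be tested is compound 4 `O=C(Nc1cccc(-c2ccc(Cl)cc2)c1)C(Cl)Cl` and it departs from compound 2 by one change chloro in place of methyl on an aromatic carbon in the form of chloro in place of methyl on an aromatic carbon, para to a large group. Within the data shown here, no measured pair isolates this change, so the expectation is anchored on compound 2 at 8300 nM as the measured compound differing in one place. In this assay no shift beyond the scatter is expected. The estimated step of a 1.2-fold lower number from compound 2 to compound 4 (0.07 log units; within the scatter) is expected to stay within the scatter. The estimate for compound 4 is 7000 nM with an expected range from 3000 nM to 16000 nM as the working figure.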

Compound 4, half-maximal inhibitory concentration: 36200 nM
Compound 4: the middle estimate sits 5.2-fold (0.71 log units) below what was measured; measured number outside the range, above it.
By their numbers in this assay, from the lowest: compounds 2 and 3 (each within the scatter of the next); then compounds 1 and 4 (each within the scatter of the next).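

In this assay, the place para to a large group proves sensitive to what sits on it: chloro in place of methyl on an aromatic carbon gives a 4.4-fold higher number from compound 2 to compound 4 (0.64 log units; beyond the scatter), a step beyond the scatter and towards weaker inhibition. The exchange is of one heavy atom for one heavy atom, with no ring, hydrogen-bond donor, hydrogen-bond acceptor or net charge entering or leaving, so even a change this small in those counts can move the number. Nothing measured here speaks to the origin of this step.

This single step does not show whether the shift is particular to chloro. From the compounds shown here alone, how an amine or a trifluoromethyl at this place would read against compound 2 at 8300 nM remains open.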